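Two Biaryl Amides Without Cytotoxicity and a Fluorophenyl Analogue

A few compounds are considered here, and "the series" means these few. Any claim that something is new, unique, unknown or untested is made for them only; others in the source may bear on it.

Measured so far:
compound 1 `CC(C)Oc1cccc(-c2ccc(C(=O)N(Cc3cccc(OCCCCCC(=O)O)c3)C(C)C)cc2)c1`, an ADME assay on BJ cells (Homo sapiens) for cytotoxicity, read by CellTiter-Glo and resazurin assay, with a stated time of 72 h; on this read-out lower numbers stand for an effect already at smaller amounts and higher numbers for an effect only at larger amounts of compound: > 26000 nM (a limit)
compound 2 `CCOC(=O)CCCCCOc1cccc(CN(C(=O)c2ccc(-c3cnc(OC)nc3OC)cc2)C(C)C)c1`, this assay: > 26000 nM (a limit)

Compound 1 reaches only a limit in this assay, > 26000 nM. Compound 2 likewise gives only a limit in this assay, > 26000 nM. Going by the values given here, neither value is a number, so no step between the two can be sized; both simply sit at the limit of > 26000 nM in this assay, at which 2 of the 2 values shown sit, and compound 2 stands at the same limit as the only other compound here.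

Compound 3 `CCOC(=O)CCCCCOc1cccc(CN(C(=O)c2ccc(-c3cc(OC)ccc3F)cc2)C(C)C)c1` has not been measured. It differs from compound 2 in a single place: 2-fluoro-5-methoxyphenyl in place of 2,4-dimethoxypyrimidin-5-yl on an aromatic carbon. Among the compounds with values here, no measured step shows what such a change does in this assay, and the evidence on hand reaches no further than the shared limit of compound 1 and compound 2.

The expectation for compound 3 is therefore that it stays at the limit, with an expected step from compound 2 of a number no higher from compound 2 to compound 3 (the limit leaves the size open), that is, none beyond the scatter. Compound 3 is estimated at 26000 nM, within a range from 10000 nM to 60000 nM, most likely reported only as a limit.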

Compound 3, half-maximal effective concentration: > 26000 nM
Compound 3 was reported as a limit; the forecaster's own chance of this, stated with the estimate: 75%; the middle value lies on the limit itself.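

Going by these compounds alone, compound 3, like compound 2, is reported only as a limit in this assay, so no step from compound 2 to compound 3 can be read: the limit of > 26000 nM in this assay, at which 3 of the 3 values shown sit.

The compounds shown leave open how 2-fluoro-5-methoxyphenyl and 2,4-dimethoxypyrimidin-5-yl compare on this read-out, and at what concentration, if any, any of the three compounds would give a measured number rather than a limit.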